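The source may hold more compounds than are shown below. What is called first, only, known or untested is meant among the compounds shown, and "the series" means these compounds.

In a functional assay on KG-1 cells (Homo sapiens) for inhibition, read by MTT assay, with a stated time of 48 h (on this read-out higher numbers stand for weaker inhibition and lower numbers for stronger inhibition), compound 1 `O=C(CCCOC(=O)c1ccc2c(c1)no[n+]2[O-])NO` gives 4020 nM and compound 2 `O=C(CCCCCOC(=O)c1ccc2c(c1)no[n+]2[O-])NO` gives 3690 nM. Compound 2 stands at the lower of the two numbers, though its gap to compound 1 lies within the scatter. Compound 3 `O=C(CCCCCCCOC(=O)c1ccc2c(c1)no[n+]2[O-])NO` differs from compound 2 in one place: 2-(hydroxycarbamoyl)ethyl in place of hydroxycarbamoyl on a saturated chain carbon, five bonds along the chain from an oxygen next to a carbonyl group. Among the measured compounds shown here, the only step that bears on this change is a 1.1-fold lower number from compound 1 to compound 2 (0.04 log units; within the scatter), which stayed within the scatter. A similar outcome is therefore expected here, a step of about a 1.1-fold lower number from compound 2 to compound 3 (0.02 log units; within the scatter), with no clear direction. Compound 3 is estimated to give 3500 nM, within a range of 1700 nM to 7200 nM.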

Compound 3, half-maximal inhibitory concentration: 5210 nM
Estimate against measurement, compound 3: 1.5-fold (0.17 log units) below; measured number inside the range.
By their numbers in this assay, from the lowest: compounds 2, 1 and 3 (each within the scatter of the next).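

Extending the chain further, with 2-(hydroxycarbamoyl)ethyl in place of hydroxycarbamoyl, brings (a 1.4-fold higher number from compound 2 to compound 3 (0.15 log units; within the scatter)), and the full extension, with 4-(hydroxycarbamoyl)butyl in place of hydroxycarbamoyl at the shorter chain, brings (a 1.3-fold higher number from compound 1 to compound 3 (0.11 log units; within the scatter)). Both steps stay within the scatter, so in this assay this position has now tolerated two rounds of chain extension without a clear change in either direction. Nothing shown here offers an explanation for these numbers. Going by these compounds, whether a longer chain would leave the number inside the scatter remains open. So does the effect of a carboxylic acid or an amine in place of the hydroxycarbamoyl end group.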